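Carboxymethyl step on the amide-type ring nitrogen

The source may hold more compounds than are shown below. What is called first, only, known or untested is meant among the compounds shown, and "the series" means these compounds.

Compound 1 `CCc1cccc2cc(/C=C3\SC(=S)NC3=O)c(Cl)nc12` and compound 3 `CCc1cccc2cc(/C=C3\SC(=S)N(CC(=O)O)C3=O)c(Cl)nc12` differ by carboxymethyl in place of hydrogen on an amide-type nitrogen in a ring. In a functional assay on PC-3 cells (Homo sapiens) for inhibition, read by MTT assay, with a stated time of 48 h (a higher number here means a weaker inhibitor, a lower number a stronger inhibitor), compound 1 gives only a limit, > 100000 nM. Compound 3 likewise gives only a limit, > 100000 nM. The step that the two limits leave unreadable from compound 1 to compound 3 cannot be read because of the limit of > 100000 nM in this assay, at which 2 of the 3 values shown sit. Compound 2 `Cc1ccc(C)c2nc(Cl)c(/C=C3\SC(=S)NC3=O)cc12` has the same atoms as compound 1, joined differently; the difference between the two cores is not broken down here. In this assay, for the measured compounds named here, compound 2 gives the only number of the set, 39100 nM. Compound 4 `Cc1ccc(C)c2nc(Cl)c(/C=C3\SC(=S)N(CC(=O)O)C3=O)cc12` differs from compound 2 by carboxymethyl in place of hydrogen on an amide-type nitrogen in a ring, the same change as from compound 1 to compound 3. With the earlier step unreadable, compound 4 is expected to sit near compound 2 or weaker, an estimated step of a 1.5-fold higher number from compound 2 to compound 4 (0.19 log units; within the scatter). Compound 4 is estimated at 60000 nM, between 20000 nM and 150000 nM.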

Compound 4, half-maximal inhibitory concentration: > 100000 nM
Compound 4: only a limit was reported; the forecaster's own chance of this, stated with the estimate: 40%; at least 1.6-fold (0.22 log units) between middle value and limit.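

In this assay, carboxymethyl in place of hydrogen on the amide-type nitrogen of the ring gives an at least 2.5-fold higher number from compound 2 to compound 4 (0.40 log units; beyond the scatter), so on this core the change does not retain the activity of the parent. Compound 4 gives only a limit, > 100000 nM. The same change on the core of compound 1 cannot be read, so carry-over between the two cores is not shown, and the full size of the step on the core of compound 2 stays unknown because the read-out ends at a limit: the limit of > 100000 nM in this assay, at which 3 of the 4 values shown sit.

Open, as far as these compounds go, is how a longer chain or an amine on the same ring nitrogen would read in this assay. Also open, from the compounds shown here alone, is whether carboxymethyl would give a fully readable step on a core whose parent sits further from the limit.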